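Branching the Amine Substituent: From Compound 1 to Compound 3

The source may report more compounds than this note shows. Statements on the series, on what has been measured and on what is new or still open speak of the compounds shown alone.

Compound 1, `CCc1cc(-c2noc(-c3cc(C)cc(CN(C)C)c3)n2)cc(C)c1OC[C@@H](O)CNC(=O)CO`, in an ADME assay on liver (strain Wistar) for metabolic stability, with Liver microsome (Rattus norvegicus) as the target, read by LC-MS, using microsomes and NADPH, with a stated time of 15 min, tested at 1 uM (on this read-out higher numbers stand for fast clearance and lower numbers for slow clearance), gives > 1250 mL.min-1.g-1.
Compound 2, `CCCCN(C)Cc1cc(C)cc(-c2nc(-c3cc(C)c(OC[C@@H](O)CNC(=O)CO)c(CC)c3)no2)c1`, in this assay gives 183 mL.min-1.g-1.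

Compound 1 stands at the edge of what this assay reports: its value is a limit of the assay, not a number, as the limit of > 1250 mL.min-1.g-1 in this assay, at which 1 of the 2 values shown sits, records. Compound 2 carries a butyl(methyl)amino group where compound 1 has a dimethylamino group, and the step of an at least 6.8-fold lower number from compound 1 to compound 2 (0.83 log units; beyond the scatter) moves the read-out down by a margin well beyond the scatter.

Compound 3, `CCc1cc(-c2noc(-c3cc(C)cc(CN(C)CC(C)C)c3)n2)cc(C)c1OC[C@@H](O)CNC(=O)CO`, is not yet measured. It differs from compound 1 in one place: isopropyl in place of hydrogen on a saturated chain carbon bound to an amine nitrogen. Within the data shown here, the only measured step that bears on this change is the one from compound 1 to compound 2, which also lengthens the chain on the same saturated carbon bound to the amine nitrogen, and which lowered the number by an at least 6.8-fold lower number from compound 1 to compound 2 (0.83 log units; beyond the scatter). A step of a similar kind and direction is therefore expected for compound 3 in this assay, that is an at least 5.0-fold lower number from compound 1 to compound 3 (0.69 log units; beyond the scatter). On that basis compound 3 is estimated at 250 mL.min-1.g-1 in this assay, with a range from 100 mL.min-1.g-1 to 700 mL.min-1.g-1.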

Compound 3, intrinsic clearance in microsomes: 20 mL.min-1.g-1
The estimate for compound 3 lay 13-fold (1.10 log units) above the measured number; measured number outside the range, below it.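

In this assay, the place on a saturated chain carbon bound to an amine nitrogen proves sensitive not only to whether a chain enters but also to which chain it is. Isopropyl in place of propyl there gives a 9.2-fold lower number from compound 2 to compound 3 (0.96 log units; beyond the scatter), so the branched isobutyl(methyl)amino group and the straight butyl(methyl)amino group are clearly not interchangeable on this read-out. Measured against the dimethylamino group, the branched chain gives an at least 62-fold lower number from compound 1 to compound 3 (1.79 log units; beyond the scatter), which shows that this single change can take the read-out far from the limit and into the low range of the values shown.

From the compounds shown here alone, the full size of every step that starts from compound 1 stays open, since compound 1 gives a limit and not a number: the limit of > 1250 mL.min-1.g-1 in this assay, at which 1 of the 3 values shown sits. Also open, going by these compounds, is whether another branched group, such as a tert-butyl or a cyclopropylmethyl group, or a ring amine such as a piperidine in place of the isobutyl(methyl)amino group, would match compound 3 in this assay.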